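Methylamino in Place of Cyclopropyl on a Carbonyl Carbon

This account rests on a few compounds, and the source may have more. Where it says the series, first, only, none or still open, it means among the compounds named here.

Compound 1 `CC(=O)N1CC2CNCC2C1` gives 36%.
Compound 2 `COC(=O)N1CC2CNCC2C1` gives 85%.
Compound 3 `O=C(C1CC1)[C@H]1C[C@@H]2CNC[C@@H](C2)C1` gives 10%.

In an assay on CHO cells for agonist activity at Neuronal acetylcholine receptor; alpha3/beta4 (Homo sapiens), read by FLIPR and calcium flux (on this read-out lower numbers stand for smaller maximal responses and higher numbers for larger maximal responses), compound 3 stands lowest of the three measured compounds, below compound 1 and far below compound 2. Within the data shown here, the only measured step, a number 49 percentage points higher from compound 1 to compound 2 (beyond the scatter), comes from methoxy in place of methyl on a carbonyl carbon and shows that a small swap at a carbonyl carbon can move the largest response a great deal. Compound 4 `CNC(=O)[C@H]1C[C@@H]2CNC[C@@H](C2)C1` differs from compound 3 by methylamino in place of cyclopropyl on a carbonyl carbon. Among the measured compounds shown here, no measured step matches this swap; the known step bears on it only loosely, as both sit on a carbonyl carbon. A rise is therefore expected, with wide uncertainty. Compound 4 is estimated at 30% (5% to 65%), an expected step of a number 20 percentage points higher from compound 3 to compound 4 (beyond the scatter).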

Compound 4, largest response reached (Emax), in percent of the reference or control that the assay uses: 5%
Estimate against measurement, compound 4: 25 percentage points above, within the range that was stated.
By their numbers in this assay, from the lowest: compounds 4 and 3 (each within the scatter of the next); then compound 1; then compound 2.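

In this assay the swap of methylamino for cyclopropyl on a carbonyl carbon gives a number 5 percentage points lower from compound 3 to compound 4 (within the scatter) and so does not separate these two groups on the core of compound 3. A swap on a carbonyl carbon therefore need not shift the response as strongly as a number 49 percentage points higher from compound 1 to compound 2 (beyond the scatter) on the core of compound 1 did. No measurement here offers a reason for this result.

On these data alone, whether methoxy would raise the response on the core of compound 3 stays open. So does the effect of dimethylamino or a longer chain such as propyl on that carbonyl carbon.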